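Working notes: methyl-to-hydrogen step on two thiophene-bearing cores

This account rests on a few compounds, and the source may have more. Where it says the series, first, only, none or still open, it means among the compounds named here.

Values come from an assay on membranes from HeLa cells for displacement of a labelled ligand from adenosine receptor A3 (Homo sapiens), read by scintillation counting, with a stated time of 180 min, tested at 1 uM; a higher number here means more inhibition at the concentration tested (going by the name of the read-out), a lower number less inhibition.
Compound 1, `CCCC(=O)C1=C(C)NC(=O)NC1c1ccsc1`, gives 1%.
Compound 2, `CC1=C(C(=O)CC(C)C)C(c2ccsc2)NC(=O)N1`, gives 14%.
Compound 3, `CCC(CC)OC(=O)C1=C(C)NC(=O)NC1c1cccs1`, gives 1%.

One measured pair differs in a single place: hydrogen in place of methyl on a saturated chain carbon bound to two saturated chain carbons. In this assay the step is a number 13 percentage points lower from compound 2 to compound 1 (beyond the scatter). Compound 3 and compound 2 carry different cores; the difference between the two cores is not broken down here. Compound 3 and compound 1 stand level at the digits printed, within the scatter.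

Compound 4, `CCC(C)OC(=O)C1=C(C)NC(=O)NC1c1cccs1`, is not yet measured. It differs from compound 3 by hydrogen in place of methyl on a saturated chain carbon, two bonds along the chain from an oxygen next to a carbonyl group. This is the same kind of change as that from compound 2 to compound 1, not the same: there the carbon was bound to two saturated chain carbons, here it lies two bonds along the chain from an oxygen next to a carbonyl group. In this assay the step from compound 3 to compound 4 is expected to be a number 1 percentage points higher from compound 3 to compound 4 (within the scatter), smaller than the measured one, because compound 3 already sits at 1% and little room remains downward. Compound 4 is thus estimated at 2%, from -6% to 14%.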

Compound 4, a percentage reported as inhibition, at one concentration (the size of the read-out at that concentration, not a potency): 7%
Beside the measured number, compound 4's estimate is 5 percentage points below it; measured number inside the range.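

In this assay, hydrogen in place of methyl on a saturated chain carbon, two bonds along the chain from an oxygen next to a carbonyl group, gives a number 6 percentage points higher from compound 3 to compound 4 (within the scatter). Set beside the step on the other core, this kind of change does not carry across as a fixed increment in this series: the same change on two cores in this assay, a number 13 percentage points lower (beyond the scatter) from compound 2 to compound 1 and a number 6 percentage points higher (within the scatter) from compound 3 to compound 4, 19 percentage points apart, beyond the scatter of two such steps

With one pair on each core and the carbon in a different place in each pair, this does not show whether the core or the place of the carbon sets the gap, and the step on the core of compound 3 gives no direction of its own.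

The compounds shown leave open whether the same change would read alike with both chains on one shared core. They also leave open how the series would respond to a longer chain at this site, or to an amine or a carboxylic acid at its end.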